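The source may hold more compounds than are shown below. What is called first, only, known or untested is meant among the compounds shown, and "the series" means these compounds.

Measured compounds in this series:

compound 1 `CC(C)(C)OC(=O)c1cccc(NC(=O)C2CCCN(C(=O)c3cc(C(F)(F)F)cc(C(F)(F)F)c3)C2)c1` — 0%
compound 2 `CS(=O)(=O)Nc1cccc(C(=O)N2CCCC(C(=O)Nc3ccc(Cl)cc3)C2)c1` — 3%
compound 3 `O=C(c1ccccc1)c1cccc(C(=O)N2CCCC(C(=O)Nc3ccc(Cl)cc3)C2)c1` — 0%

In an ADME assay on PC-3 cells (Homo sapiens) for cytotoxicity, read by WST assay, tested at 100 uM (a lower number here means less inhibition, a higher number more inhibition at the concentration tested (going by the name of the read-out)), compound 1 gives 0%, level with compound 3 at 0% and within the scatter of compound 2 at 3%; all three numbers are small and within the scatter of one another. Compound 4 `Cn1cnnc1-c1cccc(NC(=O)C2CCCN(C(=O)c3cc(C(F)(F)F)cc(C(F)(F)F)c3)C2)c1` is not yet measured; it differs from compound 1 by 4-methyl-4H-1,2,4-triazol-3-yl in place of tert-butoxycarbonyl on an aromatic carbon. Among the compounds with values here, the only measured single change, a number 3 percentage points lower from compound 2 to compound 3 (within the scatter), swaps a different group and stayed within the scatter, so it gives no sign that a group exchange on this core moves the read-out. Nothing measured suggests a step; compound 4 is expected to stay small, with a number 2 percentage points higher from compound 1 to compound 4 (within the scatter) as the estimated step. Compound 4 is therefore estimated at 2%, between 0% and 12%.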

Compound 4, a percentage reported as inhibition, at one concentration (the size of the read-out at that concentration, not a potency): 0%
The estimate for compound 4 lay 2 percentage points above the measured number; the measured number falls inside the stated range.
By their numbers in this assay, from the lowest: compounds 1, 3, 4 and 2 (each within the scatter of the next).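

In this assay, 4-methyl-4H-1,2,4-triazol-3-yl in place of tert-butoxycarbonyl gives no change at the digits printed from compound 1 to compound 4 (within the scatter). Within the data shown here, this is the first step read at this aromatic carbon, and a five-membered aromatic ring with 3 hetero atoms replaces a group with no ring without moving the read-out beyond the scatter. Nothing measured on these compounds offers an explanation for this result.

Still open, going by these compounds, is whether any group on this aromatic carbon, such as a carboxylic acid or a primary amine, gives a number beyond the scatter. Also open, on these data alone, is whether the same exchange gives a similar step on the core of compound 2.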